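Swapping Chlorines for Methoxy Groups on a Benzylamine

A few compounds are considered here, and "the series" means these few. Any claim that something is new, unique, unknown or untested is made for them only; others in the source may bear on it.

Compound 3 `Nc1cc(N)c2nc(-c3ccccc3)c(NCc3ccc(Cl)c(Cl)c3)nc2c1` carries a 3,4-dichlorophenyl group on a saturated chain carbon bound to a nitrogen on an aromatic ring. In a functional assay on OVCAR-8 cells (Homo sapiens) for inhibition, read by sulforhodamine B assay, with a stated time of 48 h (a higher number here means a weaker inhibitor of growth, a lower number a stronger inhibitor of growth), compound 3 gives 3390 nM, the lowest of the two numbers recorded. Its nearest neighbour is compound 1 `Nc1cc(N)c2nc(-c3ccccc3)c(Oc3ccc(Cl)c(Cl)c3)nc2c1`, where the same dichlorophenyl group is joined to the shared core through an oxygen rather than through the chain carbon and nitrogen; in this assay compound 1 gives 28200 nM, a gap from compound 3 that lies beyond the usual scatter. Compound 2 `CCOC(=O)[C@H](CCC(=O)O)NC(=O)c1ccc(CNc2nc3cc(N)cc(N)c3nc2-c2ccccc2)cc1` gives only a limit of the assay, < 100000 nM. That limit, (the limit of < 100000 nM in this assay, at which 1 of the 3 values shown sits), marks a boundary of what the assay reports rather than a number.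

Compound 4 `COc1ccc(CNc2nc3cc(N)cc(N)c3nc2-c2ccccc2)cc1OC` has not yet been measured. It differs from compound 3 in a single place: 3,4-dimethoxyphenyl in place of 3,4-dichlorophenyl on a saturated chain carbon bound to a nitrogen on an aromatic ring. Going by the values given here, no pair of measured compounds differs in exactly this way, so the two numbers in hand cannot fix the size of this step. Compound 4 is nonetheless expected to be a somewhat weaker inhibitor of growth than compound 3, with the step estimated at a 2.9-fold higher number from compound 3 to compound 4 (0.47 log units; beyond the scatter). In this assay compound 4 is expected to give about 10000 nM, within a range from 2500 nM to 40000 nM.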

Compound 4, concentration for 50% growth inhibition: 6760 nM
Beside the measured number, compound 4's estimate is 1.5-fold (0.17 log units) above it; the range from low to high includes it.
By their numbers in this assay, from the lowest: compounds 3 and 4 (each within the scatter of the next); then compound 1.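

In this assay, replacing 3,4-dichlorophenyl with 3,4-dimethoxyphenyl on a saturated chain carbon bound to a nitrogen on an aromatic ring gives a 2.0-fold higher number from compound 3 to compound 4 (0.30 log units; within the scatter), so this change cannot be told apart from repeat-to-repeat variation. The earlier compounds shown here offered no pair differing in one place, and this first such pair shows that the group at this position can change from one with no hydrogen-bond acceptors to one with 2, and from chlorine to oxygen atoms, without a change in growth inhibition that this assay can resolve. Nothing among the data shown explains why the two compounds cannot be separated.

As far as these compounds go, a single pair cannot show how much freedom this position allows, so it remains open whether an unsubstituted phenyl, a phenyl with a lone methoxy group, or a longer chain between the ring and the nitrogen would also stay within the scatter of compound 3. It also remains open whether the match between these two compounds would hold in other cell lines, since all the numbers shown come from this assay.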